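Para Halogen Swap on an Inactive Anilide Lactone Series

The source may report more compounds than this note shows. Statements on the series, on what has been measured and on what is new or still open speak of the compounds shown alone.

Compound 1 `O=C(CNc1ccccc1)N[C@H]1CCOC1=O` carries an unsubstituted aromatic ring. In a functional assay on PC-3 cells (Homo sapiens) for antiproliferative activity, read by MTT assay, with a stated time of 72 h (a higher number here means a weaker inhibitor, a lower number a stronger inhibitor), compound 1 gives > 64000 nM, which is a limit of the assay rather than a number. Compound 2 `O=C(CNc1ccc(Br)cc1)N[C@H]1CCOC1=O` adds bromo to that ring. In this assay compound 2 gives > 64000 nM, again only a limit. The step from compound 1 to compound 2 is therefore a step that the two limits leave unreadable from compound 1 to compound 2, as both values sit at the limit of > 64000 nM in this assay, at which 2 of the 2 values shown sit. Compound 3 `O=C(CNc1ccc(F)cc1)N[C@H]1CCOC1=O` differs from compound 2 by fluoro in place of bromo on an aromatic carbon. With no readable step to build on, the expected step from compound 2 to compound 3 is a step that the limit leaves unreadable from compound 2 to compound 3. Compound 3 is estimated at 80000 nM, within 30000 nM to 300000 nM.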

Compound 3, half-maximal inhibitory concentration: > 64000 nM
Compound 3: a limit, no number; the forecaster's own chance of this, stated with the estimate: 85%; the middle value does not contradict the limit.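

No new step can be read among compound 1, compound 2 and compound 3, as all three stop at a limit rather than a number: the limit of > 64000 nM in this assay, at which 3 of the 3 values shown sit. Going by these compounds, whether bromo, fluoro or hydrogen on the aromatic ring makes any difference in this assay stays open.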